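Cyclopentyl for isopropyl on the ring amide nitrogen

The compounds below may be only part of what the source reports. "The series", "measured", "known", "first", "only" and "open" are said of these compounds alone.

Measured so far in a functional assay on HT-29 cells (Homo sapiens) for inhibition; a lower number here means a stronger inhibitor, a higher number a weaker inhibitor:
compound 1, `COc1c(C)cnc(CN2CC(=O)N(C(C)C)c3c(Cl)nc(N)nc32)c1C`, gives 60 nM
compound 2, `COc1c(C)cnc(CN2c3nc(N)nc(Cl)c3NC(=O)[C@@H]2C)c1C`, gives 660 nM
compound 3, `COc1c(C)cnc(CN2CC(OC3CCCC3)=Nc3c(Cl)nc(N)nc32)c1C`, gives 20 nM

Compound 1 stands second highest of the three numbers in this assay. Its nearest neighbour is compound 3, whose lower number lies beyond the scatter; its furthest is compound 2, whose higher number also lies beyond the scatter. Neither pair differs from compound 1 in one place only, so the shown values say nothing about any single change.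

Compound 4, `COc1c(C)cnc(CN2CC(=O)N(C3CCCC3)c3c(Cl)nc(N)nc32)c1C`, is the next entry. It differs from compound 1 as follows: cyclopentyl in place of isopropyl on an amide-type nitrogen in a ring

Among the measured compounds shown here, no step of this kind has been measured. The change is small and alters no donor or acceptor count, so the step from compound 1 to compound 4 in this assay is expected to be modest, and if anything toward a lower number, as a 1.7-fold lower number from compound 1 to compound 4 (0.23 log units; within the scatter) expresses. For compound 4 the estimate in this assay is 35 nM, with a range from 12 nM to 120 nM.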

Compound 4, half-maximal inhibitory concentration: 330 nM
Beside the measured number, compound 4's estimate is 9.4-fold (0.97 log units) below it; measured number above the stated range.
By their numbers in this assay, from the lowest: compound 3; then compound 1; then compounds 4 and 2 (each within the scatter of the next).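

In this assay, among the compounds shown here, the change of isopropyl to cyclopentyl on the amide-type nitrogen in a ring gives a 5.5-fold higher number from compound 1 to compound 4 (0.74 log units; beyond the scatter), the first single-place step, and it shows that inhibition at this position depends on the group carried there. The larger group, with its five-membered ring of carbon only, weakens inhibition even though the donor and acceptor counts stay the same. Nothing measured on these compounds accounts for the step.

One step cannot separate the effect of the added carbon atoms from that of the ring. A cyclopropyl group or an open pentyl chain on the same nitrogen would tell these apart, and an ethyl group or a chain ending in an amine would show how far the response at this position extends.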